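Swapping the ring on the sulfur-linked chain for an open chain

The compounds below may be only part of what the source reports. "The series", "measured", "known", "first", "only" and "open" are said of these compounds alone.

Measured compounds:
compound 1 `CC1=CC(=O)OC(CSc2nc(-c3ccccc3)c(-c3ccccc3)[nH]2)C1`, 200 nM
compound 2 `c1ccc(-c2nc(SCC3CCCCO3)[nH]c2-c2ccccc2)cc1`, 210 nM
compound 3 `Clc1cccc(-c2[nH]c(SCC3CCCCO3)nc2-c2ccccc2)c1`, 560 nM

In an assay on microsomes from liver for inhibition of sterol O-acyltransferase 1 (Rattus norvegicus) (on this read-out higher numbers stand for weaker inhibition and lower numbers for stronger inhibition), compound 2 stands second highest of the three numbers, close to compound 1 and furthest from compound 3. Compound 4 `CCOC(CCSc1nc(-c2ccccc2)c(-c2ccccc2)[nH]1)OCC` differs from compound 2 by 2,2-diethoxyethyl in place of oxan-2-yl on a saturated chain carbon bound to a sulfur. The step that bears most on this change is a 1.1-fold higher number from compound 1 to compound 2 (0.02 log units; within the scatter), in which the group on the same chain carbon was exchanged without a shift beyond the scatter. The step of a 2.7-fold higher number from compound 2 to compound 3 (0.43 log units; beyond the scatter) concerns a different place and says nothing about this chain. A small step, if any, is therefore expected in this assay, in either direction. Compound 4 is expected to give about 250 nM, within 120 nM to 520 nM, meaning an expected step of a 1.2-fold higher number from compound 2 to compound 4 (0.08 log units; within the scatter).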

Compound 4, half-maximal inhibitory concentration: 69 nM
Compound 4: the middle estimate sits 3.6-fold (0.56 log units) above what was measured; the whole stated range lies above it.
By their numbers in this assay, from the lowest: compound 4; then compounds 1 and 2 (each within the scatter of the next); then compound 3.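

In this assay the group on this saturated chain carbon does matter: 2,2-diethoxyethyl in place of oxan-2-yl gives a 3.0-fold lower number from compound 2 to compound 4 (0.48 log units; beyond the scatter) and the exchange for the other ring-bearing group gives a 2.9-fold lower number from compound 1 to compound 4 (0.46 log units; beyond the scatter) as well. The earlier exchange of one ring-bearing group for the other stayed within the scatter, so only this open chain reveals that the position can respond. Nothing measured here gives a reason for these steps.

Still open, as far as these compounds go, is whether a plain hexyl chain, without the two ethoxy groups, would do as well. An amine or a carboxylic acid at the end of the chain also remains untested among the compounds shown.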